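Swapping the Aryl Group on a Cinnamamide Quinazoline

This account rests on a few compounds, and the source may have more. Where it says the series, first, only, none or still open, it means among the compounds named here.

Compound 1 `COc1ccc(OC)c(/C=C/C(=O)Nc2cc3c(Nc4ccc(F)c(Cl)c4)ncnc3cc2OC)c1`: 28600 nM
Compound 2 `COc1ccc(/C=C/C(=O)Nc2cc3c(Nc4ccc(F)c(Cl)c4)ncnc3cc2O[C@H]2CCOC2)c(OC)c1`: 2760 nM

In a functional assay on PC-3 cells (Homo sapiens) for cytotoxicity, read by MTT assay, with a stated time of 72 h (a lower number here means a stronger inhibitor, a higher number a weaker inhibitor), compound 1 gives 28600 nM, the highest number of the two, and compound 2 gives 2760 nM, a gap beyond the usual scatter. Compound 3 `COc1cc2ncnc(Nc3ccc(F)c(Cl)c3)c2cc1NC(=O)/C=C/c1ccccc1[N+](=O)[O-]` keeps the shared core and changes only the aryl group at the end of the chain: 2-nitrophenyl in place of 2,5-dimethoxyphenyl on a double-bonded chain carbon bound to a double-bonded chain carbon. Within the data shown here, no measured pair isolates this change, so a modest step is expected, a 1.9-fold lower number from compound 1 to compound 3 (0.28 log units; within the scatter), possibly toward a lower number but not clearly beyond the scatter. Compound 3 is estimated at 15000 nM, within 4000 nM to 50000 nM.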

Compound 3, half-maximal inhibitory concentration: 14300 nM
Estimate against measurement, compound 3: 1.0-fold (0.02 log units) above; the range from low to high includes it.
By their numbers in this assay, from the lowest: compound 2; then compounds 3 and 1 (each within the scatter of the next).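

Among these compounds, this is the first pair of compounds that differ in one place only, the aryl group on a double-bonded chain carbon bound to a double-bonded chain carbon. In this assay the swap to 2-nitrophenyl gives a 2.0-fold lower number from compound 1 to compound 3 (0.30 log units; within the scatter) and so shows that these two aryl groups cannot be told apart here. No supporting measurement bears on this result.

Still open, on these data alone, is whether a plain phenyl, or a phenyl carrying an amine or a carboxylic acid, would move the number beyond the scatter.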